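Inverting the Stereocentre of Compound 3

A few compounds are considered here, and "the series" means these few. Any claim that something is new, unique, unknown or untested is made for them only; others in the source may bear on it.

Three related compounds have been examined in a functional assay on the whole organism (strain Swiss CD-1) with Mus musculus as the target, in the maximal electroshock model, with stated times of 2 h and 2 s; a lower number here means that less compound is needed, a higher number that more compound is needed for the effect. Compound 1 `COCC(C(=O)N1CCN(c2cccc(Cl)c2)CC1)N1C(=O)CCC1=O` gives 79.7 mg/kg. For compound 2 `COCC(C(=O)N1CCN(c2ccc(Cl)cc2)CC1)N1C(=O)CCC1=O` the entry reads "not determined" (no result reported). Compound 3 `COC[C@@H](C(=O)N1CCN(c2ccc(C(F)(F)F)cc2)CC1)N1C(=O)CCC1=O` stands at > 120 mg/kg, which is a limit and not a number, so its position can be told only by that limit.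

Compound 4 `COC[C@H](C(=O)N1CCN(c2ccc(C(F)(F)F)cc2)CC1)N1C(=O)CCC1=O` is the counterpart of compound 3, and the difference is this: the two compounds have the same atoms and bonds and differ only in configuration as drawn: 1 of 1 stereo elements differ; a stereocentre at a saturated chain carbon is drawn S in compound 3 and R in compound 4. For the measured compounds named here, the two compounds have the same atoms and bonds, and no measured pair here shows what such an inversion does in this assay. Going by the values given here, no step beyond the scatter is expected, and any shift is expected to be toward a lower dose, as the only numerical reading in the set is compound 1 at 79.7 mg/kg. The expected change is an at least 1.2-fold lower number from compound 3 to compound 4 (0.07 log units; that floor lies within the scatter). For compound 4 the estimated dose is 100 mg/kg, with an expected range from 45 mg/kg to 220 mg/kg.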

Compound 4, dose for half-maximal effect: 80.9 mg/kg
Compound 4: middle estimate off by 1.2-fold (0.09 log units), on the high side; low and high end bracket the measured number.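

This pair isolates the configuration at the saturated chain carbon, which no earlier comparison could do: in this assay, the inversion from S to R gives an at least 1.4-fold lower number from compound 3 to compound 4 (0.17 log units; that floor lies within the scatter). For compound 3, the entry of > 120 mg/kg is a limit and not a number. The step is therefore only a floor, and any shift it records belongs to this single stereocentre: the fact that compounds 3 and 4 differ only in the configuration as drawn

The compounds shown leave open whether the same inversion would give a comparable step in the chlorine-bearing compound 1 and compound 2, whose stereocentre is drawn without a configuration. They also do not show how the R configuration would fare with a nitrile in place of the trifluoromethyl group, or with a longer chain in place of the methoxy group.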